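Phenoxy to hydroxy on the aromatic oxygen of compound 3

A few compounds are considered here, and "the series" means these few. Any claim that something is new, unique, unknown or untested is made for them only; others in the source may bear on it.

Three compounds have numbers in a functional assay on the whole organism (strain Sprague-Dawley CD) for inhibition, with Rattus norvegicus as the target, read by paw edema, at a dose of 30 mg/kg by the intraperitoneal route; a lower number here means a weaker effect, a higher number a stronger effect of the compound at the dose given. Compound 1 `CCOC(=O)C(=O)Nc1ccc(O)c(=O)cc1` gives 10%. Compound 2 `CCOC(=O)C(=O)Nc1c(Oc2ccccc2)ccccc1=O` gives 0%. Compound 3 `CCOC(=O)C(=O)Nc1ccccc(Oc2ccccc2)c1=O` gives 16%, the highest of the three numbers; its distance to compound 1 lies within the scatter, its distance to compound 2 beyond it. For the measured compounds named here, no pair among the measured compounds differs in a single place, so no step size is known from measurement.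

Compound 4 `CCOC(=O)C(=O)Nc1ccccc(O)c1=O` has not been measured. Relative to compound 3 the change is hydrogen in place of phenyl on an oxygen on an aromatic ring, which read one bond further out is phenoxy to hydroxy. Going by the values given here, compound 1 carries a hydroxy and compound 3 a phenoxy on different cores, and that pair shows only two values within the scatter of each other. With all three numbers low, no step beyond the scatter is expected, and the expected step of a number 4 percentage points lower from compound 3 to compound 4 (within the scatter) is small. Compound 4 is estimated at 12%, with a range from 0% to 28% in this assay.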

Compound 4, a percentage reported as inhibition, in the whole organism at one dose (the size of the read-out at that dose, not a potency): 61%
Compound 4: the middle estimate sits 49 percentage points below what was measured, outside the stated range (above it).
By their numbers in this assay, from the lowest: compounds 2, 1 and 3 (each within the scatter of the next, the first and the last beyond it); then compound 4.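

In this assay, for the compounds shown here, hydrogen in place of phenyl on the oxygen on an aromatic ring gives a number 45 percentage points higher from compound 3 to compound 4 (beyond the scatter), the first step that can be read across a single place. The read-out at this dose therefore depends strongly on what the oxygen carries on this core, and hydroxy is clearly preferred to phenoxy in this one matched pair. Nothing available explains the size of this step.

As far as these compounds go, it remains open whether the free hydroxy is required or whether a small group on the same oxygen, such as methyl or acetyl, or an amine in its place, would keep the effect. Also open, from the compounds shown here alone, is how the ethyl ester contributes, for example against the corresponding carboxylic acid, and how compound 4 behaves at other doses, since a single-dose read-out is not a potency.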